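Series notes: phenyl in place of pentan-3-yl

This account rests on a few compounds, and the source may have more. Where it says the series, first, only, none or still open, it means among the compounds named here.

Measured so far:
compound 1, `CCCCCCC/N=C(\NC#N)Nc1cccnc1`: > 50 mg/kg
compound 2, `CCC(CC)/N=C(\NC#N)Nc1cccnc1`: 20 mg/kg
compound 3, `CC(C)CC(C)(C)/N=C(\NC#N)Nc1cccnc1`: 2.5 mg/kg

Three compounds share one core and differ only in the group on the double-bonded nitrogen. In a functional assay on the whole organism (blood, strain Wistar-Okamoto) with Rattus norvegicus as the target, with a stated time of 5 days (a lower number here means that less compound is needed, a higher number that more compound is needed for the effect), compound 3 gives 2.5 mg/kg. Compound 2 gives 20 mg/kg in this assay, the higher of the two numbers reported, with compound 3 sitting at a lower number beyond the scatter. For compound 1 this assay reports no number, only (the limit of > 50 mg/kg in this assay, at which 1 of the 3 values shown sits). Within these three, the heptyl chain is the one that reaches only a limit, and the two branched groups give numbers; nothing further ties the values to the shape of the group.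

Compound 4, `N#CN/C(=N\c1ccccc1)Nc1cccnc1`, is not yet measured. It differs from compound 2 by phenyl in place of pentan-3-yl on a double-bonded nitrogen. Among the compounds with values here, no measured pair shows this change, so the expectation rests only on the three values above. The step of a 1.5-fold higher number from compound 2 to compound 4 (0.18 log units; within the scatter) is expected to be small and upward, likely within the usual scatter of this assay. Compound 4 is therefore expected to give about 30 mg/kg, with a range from 8 mg/kg to 100 mg/kg, and a real chance that this assay reports only a limit.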

Compound 4, minimum effective dose: 5 mg/kg
Compound 4: middle estimate off by 6.0-fold (0.78 log units), on the high side, outside the stated range (below it).
By their numbers in this assay, from the lowest: compounds 3 and 4 (each within the scatter of the next); then compound 2. At a limit, above all of these: compound 1.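

In this assay, the place on the double-bonded nitrogen accepts an aromatic ring as well as an open-chain group: phenyl in place of pentan-3-yl gives a 4.0-fold lower number from compound 2 to compound 4 (0.60 log units; beyond the scatter). Compound 3 at 2.5 mg/kg and compound 4 at 5 mg/kg lie within the scatter of each other, so a branched chain and a phenyl ring cannot be told apart in this assay, although they share little in shape. The compounds shown offer no measured basis for a cause of this step.

Going by these compounds, it remains open whether the lower number belongs to a ring in general or to the aromatic ring in particular, since a cyclohexyl group at the same place would be needed to separate the two, and whether a substituent on the phenyl ring, such as a chlorine atom or a methoxy group, would move the number in either direction. Also open, on these data alone, is whether the step from pentan-3-yl to phenyl carries over when another part of the shared core is changed, as every comparison here rests on a single core and a single whole-organism read-out.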